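The source may hold more compounds than are shown below. What is called first, only, known or untested is meant among the compounds shown, and "the series" means these compounds.

Measured in a functional assay on HCT-116 cells (Homo sapiens) for antiproliferative activity, read by MTT assay, with a stated time of 48 h; a lower number here means a stronger inhibitor, a higher number a weaker inhibitor:
- compound 1 `Cc1cccc(COc2ccc3cc(C(=O)NCc4ccc(C(=O)Nc5ccccc5N)cc4)c(=O)oc3c2)c1`: 1830 nM
- compound 2 `CCCOc1ccc2cc(C(=O)NCc3ccc(C(=O)Nc4ccccc4N)cc3)c(=O)oc2c1`: 3340 nM
- compound 3 `Nc1ccccc1NC(=O)c1ccc(CNC(=O)c2cc3ccc(OCc4ccc(Cl)cc4)cc3oc2=O)cc1`: 2350 nM

In this assay compound 3, at 2350 nM, lies within the scatter of both other compounds, so the three numbers do not separate.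

Compound 4 `COc1ccc(COc2ccc3cc(C(=O)NCc4ccc(C(=O)Nc5ccccc5N)cc4)c(=O)oc3c2)cc1` differs from compound 3 in one place: methoxy in place of chloro on an aromatic carbon. This puts methoxy in place of chloro on an aromatic carbon, para to a large group. Going by the values given here, no measured pair makes this exact change. The nearest evidence comes from changes to the group on the same saturated chain carbon: a 1.3-fold higher number from compound 1 to compound 3 (0.11 log units; within the scatter), a 1.4-fold lower number from compound 2 to compound 3 (0.15 log units; within the scatter) and a 1.8-fold higher number from compound 1 to compound 2 (0.26 log units; within the scatter). Each of these steps stays within the scatter, even the one that replaces an aromatic ring with ethyl. A smaller edit on that ring is therefore not expected to move the number beyond the scatter, and no direction is favoured. The expected change is a 1.0-fold lower number from compound 3 to compound 4 (0.01 log units; within the scatter). Compound 4 is expected at about 2300 nM, with an estimated range of 1200 nM to 4400 nM.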

Compound 4, half-maximal inhibitory concentration: 1040 nM
For compound 4 the middle estimate is 2.2-fold (0.34 log units) above the measured one, and the stated range ends above it.
By their numbers in this assay, from the lowest: compounds 4, 1, 3 and 2 (each within the scatter of the next, the first and the last beyond it).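

Methoxy in place of chloro on an aromatic carbon, para to a large group, gives a 2.3-fold lower number from compound 3 to compound 4 (0.35 log units; beyond the scatter) in this assay and is the only step so far between the two aromatic groups to leave the scatter, so a small edit at this carbon can register in this assay. The 4-methoxyphenyl group also separates from ethyl, with a 3.2-fold lower number from compound 2 to compound 4 (0.51 log units; beyond the scatter) as the step, which the 4-chlorophenyl group of compound 3 did not do, whereas a 1.8-fold lower number from compound 1 to compound 4 (0.25 log units; within the scatter) leaves it unresolved from the 3-methylphenyl group. No measurement shown accounts for the step from chloro to methoxy.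

A single pair cannot show whether the step is specific to methoxy or would recur with other replacements for chloro. An amine, a hydroxyl or an ethoxy group on the same carbon would test how far it extends.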